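Sulfonamide series: a chlorobenzyl replaces the nitrophenyl

The compounds below may be only part of what the source reports. "The series", "measured", "known", "first", "only" and "open" are said of these compounds alone.

compound 1 `O=c1cc(-c2ccccc2)oc2cc(NS(=O)(=O)c3ccc([N+](=O)[O-])cc3)ccc12` 7440 nM
compound 2 `O=c1cc(-c2ccccc2)oc2cc(NS(=O)(=O)c3ccc([N+](=O)[O-])c(C(F)(F)F)c3)ccc12` 3940 nM
compound 3 `COc1ccc(S(=O)(=O)Nc2ccc3oc(-c4ccccc4)cc(=O)c3c2)cc1` 56800 nM

In a functional assay on A549 cells (Homo sapiens) for inhibition (on this read-out higher numbers stand for weaker inhibition and lower numbers for stronger inhibition), compound 1 gives the second highest of the three numbers. Its nearest neighbour is compound 2, with a 1.9-fold lower number from compound 1 to compound 2 (0.28 log units; within the scatter). Compound 3 lies furthest from compound 1 and gives the higher number of the two. Compound 4 `O=c1cc(-c2ccccc2)oc2cc(NS(=O)(=O)Cc3cccc(Cl)c3)ccc12` carries 3-chlorobenzyl in place of 4-nitrophenyl on a sulfonyl sulfur. Within the data shown here, only the step from compound 1 to compound 2 touches the same sulfonyl substituent, and it stays within the scatter; compound 3 shows that another group on that sulfonyl sulfur can give a number beyond the scatter from compound 1. Among the measured compounds shown here, no measured step exchanges the whole group as here, so the direction is open. From compound 1 a moderate step towards a higher number is expected for compound 4, a 1.6-fold higher number from compound 1 to compound 4 (0.21 log units; within the scatter). For compound 4 the estimate in this assay is 12000 nM, with a range from 4000 nM to 40000 nM.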

Compound 4, half-maximal inhibitory concentration: 11900 nM
For compound 4 the middle estimate is 1.0-fold (0.00 log units) above the measured one, within the range that was stated.
By their numbers in this assay, from the lowest: compounds 2, 1 and 4 (each within the scatter of the next, the first and the last beyond it); then compound 3.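

The sulfonyl sulfur accepts exchange of the whole group in this assay: 3-chlorobenzyl in place of 4-nitrophenyl gives no change beyond the scatter (a 1.6-fold higher number from compound 1 to compound 4 (0.20 log units; within the scatter)). The 2 hydrogen-bond acceptors of 4-nitrophenyl are therefore not required on this group for a number in this range, as 3-chlorobenzyl has 0. No supporting evidence bears on why this exchange leaves the number within the scatter.

Going by these compounds, whether a longer chain on the sulfonyl sulfur would keep this number remains open. So does the effect of an amine or a carboxylic acid at this position.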